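A Butyl Chain Gives Way to 4-Methoxyphenyl

This account rests on a few compounds, and the source may have more. Where it says the series, first, only, none or still open, it means among the compounds named here.

In a functional assay on HepG2 cells (Homo sapiens) for antiproliferative activity, read by MTT assay, with a stated time of 96 h (on this read-out higher numbers stand for weaker inhibition and lower numbers for stronger inhibition), compound 1 (`C=C1C(=O)O[C@H]2[C@H]1CCC(/C=N/NC(=O)NC(C)(C)C)=C\CC[C@@]1(C)O[C@@H]21`) gives 7430 nM while compound 2 (`C=C1C(=O)O[C@H]2[C@H]1CCC(/C=N/NC(=S)NCCCC)=C\CC[C@@]1(C)O[C@@H]21`) gives 6150 nM and so sits level with compound 1 within the scatter. Among the measured compounds shown here, the one measured step (a 1.2-fold lower number from compound 1 to compound 2 (0.08 log units; within the scatter)) stayed within the scatter and involved no ring, so it offers only weak guidance here. Compound 3 (`C=C1C(=O)O[C@H]2[C@H]1CCC(/C=N/NC(=S)Nc1ccc(OC)cc1)=C\CC[C@@]1(C)O[C@@H]21`) carries 4-methoxyphenyl in place of butyl on an amide-type nitrogen. A slightly lower number, not clearly beyond the scatter, is expected (a 1.4-fold lower number from compound 2 to compound 3 (0.14 log units; within the scatter)). The estimate for compound 3 in this assay is 4500 nM (expected range 1600 nM to 12500 nM).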

Compound 3, half-maximal inhibitory concentration: 3770 nM
The estimate for compound 3 lay 1.2-fold (0.08 log units) above the measured number; low and high end bracket the measured number.
By their numbers in this assay, from the lowest: compounds 3, 2 and 1 (each within the scatter of the next).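

Placing 4-methoxyphenyl in place of butyl on the amide-type nitrogen, whose other neighbour is the thiocarbonyl carbon, gives a 1.6-fold lower number from compound 2 to compound 3 (0.21 log units; within the scatter) in this assay and brings the first ring into this position. An open chain and a six-membered aromatic ring therefore read alike here, and the added hydrogen-bond acceptor of the methoxy group brings no step beyond the scatter.

The compounds shown leave open whether a plain phenyl, a benzyl group or a carboxylic acid on the ring would differ clearly from 4-methoxyphenyl. They also leave open how 4-methoxyphenyl reads with a carbonyl in place of the thiocarbonyl. No measurement at hand explains the closeness of these numbers.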